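Fluorobenzyl Replaces Difluorophenyl on the Ring Nitrogen

This account rests on a few compounds, and the source may have more. Where it says the series, first, only, none or still open, it means among the compounds named here.

Compound 2 `O=C(O)c1ccc(COc2ccc(/C=C3\SC(=S)N(c4c(F)cccc4F)C3=O)cc2)cc1` stands at the edge of what could be measured: in an assay on isolated protein for inhibition of Apoptosis regulator Bcl-2 (Homo sapiens), read by fluorescence polarization (on this read-out lower numbers stand for stronger inhibition and higher numbers for weaker inhibition), compound 2 gives > 10000 nM, a limit of the assay rather than a number (the limit of > 10000 nM in this assay, at which 1 of the 2 values shown sits). Compound 1 `O=C(O)c1ccc(COc2ccc(/C=C3\SC(=S)N(c4ccc(Br)cc4)C3=O)cc2)cc1` gives 610 nM, so the change an at least 16-fold higher number from compound 1 to compound 2 (1.21 log units; beyond the scatter) was a large loss. Compound 3 `O=C(O)c1ccc(COc2ccc(/C=C3\SC(=S)N(Cc4ccc(F)cc4)C3=O)cc2)cc1` differs from compound 2 by 4-fluorobenzyl in place of 2,6-difluorophenyl on an amide-type nitrogen in a ring. For the measured compounds named here, only that one measured step bears on this change, and it was large; the new group moves away from the arrangement that produced it, so partial recovery is expected. Compound 3 is therefore estimated at 3000 nM, between 800 nM and 10000 nM, an expected step of an at least 3.3-fold lower number from compound 2 to compound 3 (0.52 log units; beyond the scatter).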

Compound 3, inhibition constant: > 10000 nM
Compound 3 gave a limit, no number (the forecaster's own chance of this, stated with the estimate: 35%); middle value at least 3.3-fold (0.52 log units) from the limit.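

In this assay, a second replacement of the 4-bromophenyl group on the ring nitrogen also fails to keep a readable value, with an at least 16-fold higher number from compound 1 to compound 3 (1.21 log units; beyond the scatter). The value of compound 3 is a limit, like that of compound 2, so the step between these two cannot be read: the limit of > 10000 nM in this assay, at which 2 of the 3 values shown sit. Of the three groups shown at this position, only 4-bromophenyl gives a number. Going by these compounds, it remains open whether 4-bromobenzyl or 4-chlorophenyl on the same nitrogen would give a number, and no ranking of 2,6-difluorophenyl against 4-fluorobenzyl can be drawn.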